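Triazole Aryl Swap on a Weakly Active Spiro Scaffold

The compounds below may be only part of what the source reports. "The series", "measured", "known", "first", "only" and "open" are said of these compounds alone.

Among the compounds with values here, compound 2 `N#CC1=C(N)Oc2c(N)cc3nc4ccccc4nc3c2C12C(=O)N(Cc1cnnn1-c1ccccc1Br)c1ccccc12` was tested in a functional assay on HepG2 cells (Homo sapiens) for antiproliferative activity, read by MTT assay, with a stated time of 48 h (on this read-out higher numbers stand for weaker inhibition and lower numbers for stronger inhibition), where compound 2 gives 38000 nM, the only full number among the measurements. Compound 1 `Cc1ccc(-n2nncc2CN2C(=O)C3(C(C#N)=C(N)Oc4c3c3nc5ccccc5nc3c3ccccc43)c3ccccc32)cc1C` gives only a limit in this assay, namely > 50000 nM. Compound 3 `CCc1cccc(C)c1-n1nncc1CN1C(=O)C2(C(C#N)=C(N)Oc3c(N)cc4nc5ccccc5nc4c32)c2ccccc21` has not yet been measured; it differs from compound 2 by 2-ethyl-6-methylphenyl in place of 2-bromophenyl on an aromatic nitrogen. Within the data shown here, with no measured step of this kind to draw on, the change is expected to shift activity little, if at all, beyond the usual scatter, so the weak level of compound 2 should carry over. Compound 3 is therefore estimated to give 45000 nM, within 20000 nM to 100000 nM, in this assay. This expectation means a step of a 1.2-fold higher number from compound 2 to compound 3 (0.07 log units; within the scatter).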

Compound 3, half-maximal inhibitory concentration: > 50000 nM
Compound 3 gave a limit, no number (the forecaster's own chance of this, stated with the estimate: 50%); middle value at least 1.1-fold (0.04 log units) away from the limit.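

In this assay compound 3 gives > 50000 nM as a limit and not a number. Placing 2-ethyl-6-methylphenyl where 2-bromophenyl stood on the aromatic nitrogen gives an at least 1.3-fold higher number from compound 2 to compound 3 (0.11 log units; that floor lies within the scatter) and so brings no gain in activity at this position, although whether it brings a real loss stays undecided. Going by these compounds, the true size of this step stays unknown because the read-out ends at a limit: the limit of > 50000 nM in this assay, at which 2 of the 3 values shown sit.

On these data alone, whether an amine or a carboxylic acid on the phenyl ring at this position would bring stronger inhibition than compound 2 shows remains open.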